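The compounds below may be only part of what the source reports. "The series", "measured", "known", "first", "only" and "open" are said of these compounds alone.

Measured so far in an ADME assay on the whole organism (Rattus norvegicus, strain Sprague-Dawley) for pharmacokinetics, read by LC-MS, with a stated time of 30 min, at a dose of 1 mg/kg by the intravenous route; a higher number here means faster removal of the compound, a lower number slower removal:
compound 1 `N#Cc1ccc(O[C@H]2CN(S(=O)(=O)c3ccc(C(F)(F)F)cc3)C[C@@]2(O)CO)cc1F` gives 1500 mL/min/kg
compound 2 `N#Cc1ccc(O[C@H]2CN(S(=O)(=O)c3ccc(Cl)cc3Cl)C[C@@]2(O)CN)cc1F` gives 1100 mL/min/kg
compound 3 `N#Cc1ccc(O[C@H]2CN(S(=O)(=O)c3ccc(Cl)cc3Cl)C[C@]2(O)CO)cc1F` gives 1350 mL/min/kg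

All three compounds share a core and are cleared quickly in this assay. Compound 2 has the smallest of the three numbers, but its gaps to compound 3 and to compound 1 both lie within the usual scatter of repeated measurements, so the three compounds cannot be told apart on these data.

Compound 4 `N#Cc1ccc(O[C@H]2CN(S(=O)(=O)c3ccc(Cl)cn3)C[C@@]2(O)CN)cc1F` has not yet been measured. It differs from compound 2 in one place: 5-chloropyridin-2-yl in place of 2,4-dichlorophenyl on a sulfonyl sulfur. Among the measured compounds shown here, no measured pair shows the effect of such a swap, so there is no step to lean on. With the three known compounds sitting so close together, the expectation for compound 4 in this assay is a number that stays in the same region as compound 2, with a step from compound 2 to compound 4 that is estimated at a 1.1-fold lower number from compound 2 to compound 4 (0.04 log units; within the scatter) and is not expected to go beyond the scatter in either direction. Compound 4 is therefore estimated at 1000 mL/min/kg, with a range from 600 mL/min/kg to 1700 mL/min/kg.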

Compound 4, clearance: 320 mL/min/kg
Beside the measured number, compound 4's estimate is 3.1-fold (0.49 log units) above it; the measured number lies below the stated range.
By their numbers in this assay, from the lowest: compound 4; then compounds 2, 3 and 1 (each within the scatter of the next).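

In this assay, among the compounds shown here, the group on the sulfonyl sulfur turns out to matter: 5-chloropyridin-2-yl in place of 2,4-dichlorophenyl gives a 3.4-fold lower number from compound 2 to compound 4 (0.54 log units; beyond the scatter) and so separates a compound from the others for the first time. Compound 4 is also the only compound shown with a hetero atom in this aromatic ring, so this single change opens a route to slower removal that the earlier compounds, all carrying a carbon-only ring here, could not reveal. No measurement at hand explains why the removal slows.

The swap adds a ring nitrogen and drops a chlorine at the same time, so the compounds shown cannot say which of the two matters. A plain phenyl, a 4-chlorophenyl or an unsubstituted pyridin-2-yl on the sulfonyl sulfur would begin to pull these two apart.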